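This account rests on a few compounds, and the source may have more. Where it says the series, first, only, none or still open, it means among the compounds named here.

Measured so far:
Compound 1 `COc1ccc(-c2c(Nc3ccc(C)c(O)c3)c3ccc(OC)cc3oc2=O)cc1` gives 31300 nM
Compound 2 `COc1ccc(-c2c(Nc3ccc(NC(C)=O)cc3)c3ccc(OC)cc3oc2=O)cc1` gives "not determined" (no result reported)

In a functional assay on PANC-1 cells (Homo sapiens) for antiproliferative activity, read by MTT assay, with a stated time of 48 h (a lower number here means a stronger inhibitor, a higher number a weaker inhibitor), compound 2 gives "not determined" (no result reported) and so has no number to set beside that of compound 1. The change 3-(trifluoromethyl)phenyl in place of 4-acetamidophenyl on a nitrogen on an aromatic ring leads to compound 3 `COc1ccc(-c2c(Nc3cccc(C(F)(F)F)c3)c3ccc(OC)cc3oc2=O)cc1` and puts 3-(trifluoromethyl)phenyl in place of 4-acetamidophenyl on a nitrogen on an aromatic ring. Among the compounds with values here, no measured step exists to size this change. Within the data shown here, compound 3 is therefore expected to show no shift beyond the usual scatter in this assay from the one available number, where compound 1 gives 31300 nM as the reference. For compound 3 the estimated value is 25000 nM with an expected range of 8000 nM to 70000 nM in this measurement.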

Compound 3, half-maximal inhibitory concentration: 39500 nM
Compound 3: the middle estimate sits 1.6-fold (0.20 log units) below what was measured, and the stated range covers the measured number.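

In this assay, within the data shown here, the step of a 1.3-fold higher number from compound 1 to compound 3 (0.10 log units; within the scatter) gives the only reading so far at this place on the nitrogen: exchanging 3-hydroxy-4-methylphenyl for 3-(trifluoromethyl)phenyl leaves the number within the scatter. The step from compound 2 cannot be read, as compound 2 has no number. Nothing at hand bears on why this exchange behaves as it does.

From the compounds shown here alone, whether any group on this nitrogen can move the number beyond the scatter remains open. A phenyl carrying an amine or a carboxylic acid, or a longer alkyl chain in place of the aromatic ring, would be one way to find out.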